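From Chloromethyl to Bromomethyl on the Shared Core

A few compounds are considered here, and "the series" means these few. Any claim that something is new, unique, unknown or untested is made for them only; others in the source may bear on it.

Measured in a functional assay on KYSE-450 cells (Homo sapiens) for inhibition, read by MTT assay, with a stated time of 48 h; a lower number here means a stronger inhibitor, a higher number a weaker inhibitor:
Compound 1 `COc1ccc(CN(C(=O)C(C)Br)c2cc(OC)c(OC)c(OC)c2)cc1O`: 160 nM
Compound 2 `C/C=C/C=C/C(=O)N(Cc1ccc(OC)c(O)c1)c1cc(OC)c(OC)c(OC)c1`: 180 nM
Compound 3 `COc1ccc(CN(C(=O)CCl)c2cc(OC)c(OC)c(OC)c2)cc1O`: 210 nM

Compound 3 stands level with the other two, as the measured steps show: a 1.3-fold higher number from compound 1 to compound 3 (0.12 log units; within the scatter) and a 1.2-fold higher number from compound 2 to compound 3 (0.07 log units; within the scatter). Compound 4 `COc1ccc(CN(C(=O)CBr)c2cc(OC)c(OC)c(OC)c2)cc1O` carries bromo in place of chloro on a saturated chain carbon bound to a carbonyl carbon. For the measured compounds named here, no measured step isolates this swap. The closest comparison is a 1.3-fold higher number from compound 1 to compound 3 (0.12 log units; within the scatter), and the larger replacement in a 1.2-fold higher number from compound 2 to compound 3 (0.07 log units; within the scatter) also stays small. No step beyond the scatter is therefore expected in this assay, and the expected step is a 1.2-fold lower number from compound 3 to compound 4 (0.09 log units; within the scatter). For compound 4 the estimated value is 170 nM, with an expected range of 90 nM to 320 nM.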

Compound 4, half-maximal inhibitory concentration: 120 nM
Compound 4: the middle estimate sits 1.4-fold (0.15 log units) above what was measured; the range from low to high includes it.
By their numbers in this assay, from the lowest: compounds 4, 1, 2 and 3 (each within the scatter of the next).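

Bromo in place of chloro on a saturated chain carbon bound to a carbonyl carbon, now isolated as a single swap in this assay, gives a 1.8-fold lower number from compound 3 to compound 4 (0.24 log units; within the scatter), so this position holds level with either halogen. Bromomethyl also stays level with the much larger penta-1,3-dien-1-yl, at a 1.5-fold lower number from compound 2 to compound 4 (0.18 log units; within the scatter), and hydrogen in place of methyl on the bromine-bearing carbon gives a 1.3-fold lower number from compound 1 to compound 4 (0.12 log units; within the scatter). Nothing available bears on what lies behind these numbers. The compounds shown leave open whether iodo, an amine or a hydroxyl on that carbon would stay level with bromo, and whether a longer chain carrying bromo would do the same.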